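A few compounds are considered here, and "the series" means these few. Any claim that something is new, unique, unknown or untested is made for them only; others in the source may bear on it.

Of the compounds shown here, three have been measured in a functional assay on U-87MG ATCC cells for antiproliferative activity against U-87 MG (Homo sapiens), read by MTT assay, with a stated time of 48 h, tested at 10 uM; a lower number here means a stronger effect, a higher number a weaker effect of the compound at the concentration tested. Among the compounds with values here, compound 1 `Cc1nc(-c2ccc(Cl)cc2)sc1C(=O)CSc1nc(-c2ccccc2)c(C#N)c(=O)[nH]1` gives 83.1% and compound 3 `Cc1nc(-c2ccc(Cl)cc2)sc1C(=O)CSc1nc(-c2cccc(Cl)c2)c(C#N)c(=O)[nH]1` gives 95.2%; the one measured step between them, a number 12.1 percentage points higher from compound 1 to compound 3 (beyond the scatter), is chloro in place of hydrogen on an aromatic carbon. Compound 2 `COc1ccc(-c2nc(SCC(=O)c3sc(-c4ccccc4)nc3C)[nH]c(=O)c2C#N)cc1` gives 90.4%, the second highest of the three numbers and within the scatter of both compound 3 and compound 1. Compound 4 `COc1ccc(-c2nc(SCC(=O)c3sc(-c4ccccc4)nc3C)[nH]c(=O)c2C#N)cc1OC` has not yet been measured; it differs from compound 2 by methoxy in place of hydrogen on an aromatic carbon. Within the data shown here, no measured step covers a methoxy entering; the only measured step, a group added on an aromatic carbon, was modest. The step expected is a number 2.6 percentage points higher from compound 2 to compound 4 (within the scatter), within the scatter. Compound 4 is expected to give 93%, between 84% and 100%.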

Compound 4, a percentage reported as activity, at one concentration (the size of the read-out at that concentration, not a potency): 69.8%
Beside the measured number, compound 4's estimate is 23.2 percentage points above it; measured number outside the range, below it.
By their numbers in this assay, from the lowest: compound 4; then compounds 1, 2 and 3 (each within the scatter of the next, the first and the last beyond it).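

In this assay the change from 4-methoxyphenyl to 3,4-dimethoxyphenyl gives a number 20.6 percentage points lower from compound 2 to compound 4 (beyond the scatter), the first measured step towards a lower number, whereas a number 12.1 percentage points higher from compound 1 to compound 3 (beyond the scatter) runs the other way. A group added on an aromatic carbon therefore does not shift the number in one direction across these compounds. Nothing available explains the drop at this place.

From the compounds shown here alone, whether it needs the methoxy group already present on the ring remains open. So does whether an ethoxy group or an amine entering at the same place would give a similar step.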